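Hydroxy to methoxy on a weak growth inhibitor

The compounds below may be only part of what the source reports. "The series", "measured", "known", "first", "only" and "open" are said of these compounds alone.

Compound 1 `COc1cc(C(=O)c2ccc(OC)c(O)c2OC)cc(OC)c1O` gives 100000 nM
Compound 2 `COc1cc(C(=O)c2ccc3c(c2)oc(=O)n3S(C)(=O)=O)cc(OC)c1OC` gives 11300 nM

In a functional assay on SK-MEL-28 cells (Homo sapiens) for cytotoxicity, read by sulforhodamine B assay, with a stated time of 48 h (a lower number here means a stronger inhibitor of growth, a higher number a weaker inhibitor of growth), compound 1 stands highest of the two numbers, and compound 2 lies lower by more than the scatter. Compound 3 `COc1ccc(C(=O)c2cc(OC)c(OC)c(OC)c2)c(OC)c1O` differs from compound 1 by methyl in place of hydrogen on an oxygen on an aromatic ring, which reads as hydroxy to methoxy. For the measured compounds named here, no measured pair shows this change. Support for expecting a fall is thin. Going by the values given here, compound 2 at 11300 nM shows only that lower values occur here. The expected change is a drop beyond the scatter, estimated as a 20-fold lower number from compound 1 to compound 3 (1.30 log units; beyond the scatter). Compound 3 is expected at 5000 nM (estimated range 300 nM to 50000 nM).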

Compound 3, concentration for 50% growth inhibition: 9460 nM
Compound 3: middle estimate off by 1.9-fold (0.28 log units), on the low side; low and high end bracket the measured number.
By their numbers in this assay, from the lowest: compounds 3 and 2 (each within the scatter of the next); then compound 1.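

In this assay, for the compounds shown here, methyl in place of hydrogen on an oxygen on an aromatic ring gives an 11-fold lower number from compound 1 to compound 3 (1.02 log units; beyond the scatter), a large step and the first measured pair to isolate a single change. It shows that growth inhibition responds strongly to this one hydroxy to methoxy change, with a single added carbon accounting for the whole difference. No measurement shown explains the step.

The compounds shown leave open whether ethyl or a longer chain on this oxygen would lower the number further than methyl. An amine in place of the hydroxy also remains an open case.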